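The compounds below may be only part of what the source reports. "The series", "measured", "known", "first", "only" and "open" are said of these compounds alone.

Of the compounds shown here, three built on one shared core have been measured in an ADME assay on L6 cells (Rattus norvegicus) for cytotoxicity, read by resazurin assay, with a stated time of 70 h; on this read-out lower numbers stand for stronger inhibition and higher numbers for weaker inhibition. Compound 1 `COc1ccc(/C=C/C(=O)NCCCC(C)Nc2cc(OC)cc3cccnc23)cc1` carries a 4-methoxyphenyl on the double-bonded chain; in this assay compound 1 reaches only the limit > 100 ug/mL, which is a limit and not a number (the limit of > 100 ug/mL in this assay, at which 1 of the 3 values shown sits). Compound 2 `COc1cc(NC(C)CCCNC(=O)/C=C/c2ccc(Cl)cc2)c2ncccc2c1` carries a 4-chlorophenyl there, and in this assay compound 2 gives 7.1 ug/mL. Compound 3 `COc1cc(NC(C)CCCNC(=O)/C=C/c2cccc(C(F)(F)F)c2)c2ncccc2c1` carries a 3-(trifluoromethyl)phenyl, and in this assay compound 3 gives 7.4 ug/mL, the highest of the two numbers recorded, with compound 2 sitting within the scatter of it.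

Compound 4 `COc1cc(NC(C)CCCNC(=O)/C=C/c2cc(C(F)(F)F)cc(C(F)(F)F)c2)c2ncccc2c1` has not yet been measured. It differs from compound 3 by trifluoromethyl in place of hydrogen on an aromatic carbon. For the measured compounds named here, no measured step repeats exactly this change. The steps that come nearest are an at least 13-fold lower number from compound 1 to compound 3 (1.13 log units; beyond the scatter) and a 1.0-fold higher number from compound 2 to compound 3 (0.02 log units; within the scatter), which together show that exchanging the aryl substituent moved the number a lot in one case and not at all in the other; the change from compound 3 to compound 4 keeps the first trifluoromethyl and only adds a second. In this assay the step from compound 3 to compound 4 is therefore expected to be small, a 1.5-fold lower number from compound 3 to compound 4 (0.17 log units; within the scatter), and compound 4 is estimated at 5 ug/mL, between 2 ug/mL and 12 ug/mL.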

Compound 4, half-maximal inhibitory concentration: 83.1 ug/mL
Compound 4: middle estimate off by 17-fold (1.22 log units), on the low side, and the stated range ends below it.
By their numbers in this assay, from the lowest: compounds 2 and 3 (each within the scatter of the next); then compound 4. At a limit, above all of these: compound 1.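

In this assay, the added trifluoromethyl, on an aromatic carbon meta to a large group and meta to a trifluoromethyl group, gives an 11-fold higher number from compound 3 to compound 4 (1.05 log units; beyond the scatter), so a change at this position can move the number strongly. The earlier step of a 1.0-fold higher number from compound 2 to compound 3 (0.02 log units; within the scatter) had not shown this, since exchanging 4-chlorophenyl for 3-(trifluoromethyl)phenyl left the number within the scatter, and a first trifluoromethyl on the ring therefore says little about what a second one does. Compound 1 remains the only compound on the weak side without a number, as its result is a limit: the limit of > 100 ug/mL in this assay, at which 1 of the 4 values shown sits.

From the compounds shown here alone, whether an amine, a carboxylic acid or a methoxy group on that same aromatic carbon would move the number as far as the second trifluoromethyl does remains open, so the step cannot yet be tied to this group rather than to any added group at this position. Also open, going by these compounds, is whether the step would keep its size with a longer chain in place of the one that joins the amide to the shared core.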